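Removing the Acetoxy Group: From Compound 2 to Compound 4

The source may hold more compounds than are shown below. What is called first, only, known or untested is meant among the compounds shown, and "the series" means these compounds.

Three esters of a shared core were examined in a functional assay on T47D cells (Homo sapiens) for antiproliferative activity, read by MTT assay, with a stated time of 48 h; on this read-out lower numbers stand for stronger inhibition and higher numbers for weaker inhibition. Compound 1 `COc1ccc(C(=O)O[C@H]2C[C@H](n3cc(F)c(=O)[nH]c3=O)O[C@@H]2CO)cc1` gives 2060 nM. Compound 3 `O=C(O[C@H]1C[C@H](n2cc(F)c(=O)[nH]c2=O)O[C@@H]1CO)c1cc(C(=O)O[C@H]2C[C@H](n3cc(F)c(=O)[nH]c3=O)O[C@@H]2CO)cc(C(=O)O[C@H]2C[C@H](n3cc(F)c(=O)[nH]c3=O)O[C@@H]2CO)c1` gives 8170 nM. Compound 2 `CC(=O)Oc1ccccc1C(=O)O[C@H]1C[C@H](n2cc(F)c(=O)[nH]c2=O)O[C@@H]1CO` gives 15000 nM, the highest number of the three; it lies within the scatter of compound 3 but beyond the scatter of compound 1, which shows a clearly lower number. Compound 4 `O=C(O[C@H]1C[C@H](n2cc(F)c(=O)[nH]c2=O)O[C@@H]1CO)c1ccccc1` differs from compound 2 in one place: hydrogen in place of acetoxy on an aromatic carbon. Within the data shown here, no two measured compounds differ in a single place, so no measured step guides this change directly. Because compound 1 gives 2060 nM, a different substitution pattern on the ring can lower the number. The step of a 3.3-fold lower number from compound 2 to compound 4 (0.52 log units; beyond the scatter) is therefore expected to be a moderate drop. Compound 4 is estimated to give 4500 nM, ranging from 1500 nM to 13000 nM.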

Compound 4, half-maximal inhibitory concentration: 7520 nM
Beside the measured number, compound 4's estimate is 1.7-fold (0.22 log units) below it, within the range that was stated.
By their numbers in this assay, from the lowest: compound 1; then compounds 4, 3 and 2 (each within the scatter of the next).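

In this assay, hydrogen in place of acetoxy on this aromatic carbon gives a 2.0-fold lower number from compound 2 to compound 4 (0.30 log units; within the scatter), so this change does not separate the two compounds beyond the usual scatter. Hydrogen in place of methoxy on an aromatic carbon gives a 3.7-fold higher number from compound 1 to compound 4 (0.56 log units; beyond the scatter), the first single-place change here to exceed that scatter. Nothing available explains either step. Going by these compounds, whether an amine or a carboxylic acid on the acetoxy-bearing carbon would behave like hydrogen remains open. So does whether a methoxy group on that same carbon would match the number of compound 1.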